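Swapping the sulfur substituent in a thioether chalcone-like series

The source may report more compounds than this note shows. Statements on the series, on what has been measured and on what is new or still open speak of the compounds shown alone.

Measured so far:
- compound 2, `Cc1ccc(C)c(/C=C(/Sc2ccc(Br)cc2)C(=O)c2ccc(Cl)cc2)c1`: 10000 nM
- compound 1, `O=C(/C(=C\c1ccc(O)cc1O)Sc1ccc(Br)cc1)c1ccc(Cl)cc1`: 50000 nM

In a functional assay on DU-145 cells (Homo sapiens) for inhibition, read by trypan blue exclusion, with a stated time of 96 h (a lower number here means a stronger inhibitor of growth, a higher number a weaker inhibitor of growth), compound 2 gives the lower of the two numbers, and compound 1 gives 50000 nM. For the measured compounds named here, the one measured step, a 5.0-fold lower number from compound 1 to compound 2 (0.70 log units; beyond the scatter), concerns the group on the double-bonded chain carbon, not the sulfur.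

Compound 3, `Cc1ccc(C)c(/C=C(/SCc2ccc(Cl)cc2)C(=O)c2ccc(Cl)cc2)c1`, is not yet measured. It differs from compound 2 as follows: 4-chlorobenzyl in place of 4-bromophenyl on a sulfur. Going by the values given here, no measured step touches the sulfur substituent, so nothing in the data shows how this change plays out, and the step cannot be anchored to compound 1 or compound 2. Compound 3 is therefore expected to sit close to compound 2, with a wide range, as no change at the digits printed from compound 2 to compound 3 (within the scatter). The estimate for compound 3 in this assay is 10000 nM, between 2500 nM and 40000 nM.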

Compound 3, concentration for 50% growth inhibition: 10000 nM
Compound 3: middle estimate and measured number agree at the digits printed; the range from low to high includes it.
By their numbers in this assay, from the lowest: compounds 2 and 3 (each within the scatter of the next); then compound 1.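

The earlier compounds shown here said nothing about the sulfur substituent, but in this assay 4-chlorobenzyl in place of 4-bromophenyl on a sulfur now gives no change at the digits printed from compound 2 to compound 3 (within the scatter). With the 2,5-dimethylphenyl group held fixed, this position therefore accepts the move from a 7-heavy-atom group to an 8-heavy-atom group, with bromine giving way to chlorine, and the growth-inhibition number stays within the scatter. Nothing measured here accounts for this result.

The compounds shown change the halogen and the heavy-atom count together, so it remains open whether each change alone would leave the number in place or whether the two offset each other. Also open, from the compounds shown here alone, is how a carboxylic acid, an amine or a longer chain would read on the sulfur, and whether the same swap would hold with the 2,4-dihydroxyphenyl group of compound 1.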